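Replacing the chloro-nitrophenyl arm with an aminophenyl arm

The compounds below may be only part of what the source reports. "The series", "measured", "known", "first", "only" and "open" are said of these compounds alone.

Among the compounds with values here, compound 1 `CCOC(=O)C1=C(C)NC(=O)NC1c1cn(C(=O)CNc2ccc([N+](=O)[O-])cc2Cl)c2ccccc12` is the only compound in this set with a numerical result: in a functional assay on HCT-116 cells (Homo sapiens) for cytotoxicity, read by MTT assay, with a stated time of 72 h (a lower number here means a stronger inhibitor, a higher number a weaker inhibitor), compound 1 gives 5 ug/mL. Compound 2 `CCOC(=O)C1=C(C)NC(=S)NC1c1cn(C(=O)CNc2ccccc2[N+](=O)[O-])c2ccccc12` sits at the limit of > 1000 ug/mL in this assay, at which 1 of the 2 values shown sits. In this assay compound 2 returns > 1000 ug/mL, which is a limit of the assay and not a number. Compound 3 `CCOC(=O)C1=C(C)NC(=O)NC1c1cn(C(=O)CNc2ccccc2N)c2ccccc12` has not yet been measured; it differs from compound 1 by 2-aminophenyl in place of 2-chloro-4-nitrophenyl on an amine nitrogen. Within the data shown here, no measured step covers this change, so the expectation is a modest move toward a weaker inhibitor, as a step of a 3.0-fold higher number from compound 1 to compound 3 (0.48 log units; beyond the scatter). Compound 3 is estimated at 15 ug/mL, with a range from 3 ug/mL to 100 ug/mL.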

Compound 3, half-maximal inhibitory concentration: 300 ug/mL
Compound 3: the middle estimate sits 20-fold (1.30 log units) below what was measured; measured number above the stated range.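

In this assay, putting 2-aminophenyl in place of 2-chloro-4-nitrophenyl on the amine nitrogen gives a 60-fold higher number from compound 1 to compound 3 (1.78 log units; beyond the scatter). Within the data shown here, this is the first measured step at this position, and it shows that activity here depends strongly on the group carried by that nitrogen. Nothing shown here accounts for the size of this loss. From the compounds shown here alone, the change removes the chloro and nitro groups and adds the amine in a single step, so their separate contributions remain open. A plain phenyl arm, or one carrying only chloro or only nitro, would help to separate them.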